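The compounds below may be only part of what the source reports. "The series", "measured", "known", "first", "only" and "open" are said of these compounds alone.

Measured in a functional assay on MCF7 cells (Homo sapiens) for antiproliferative activity, read by MTT assay, with a stated time of 24 h (a lower number here means a stronger inhibitor, a higher number a weaker inhibitor), as follows
- compound 1 `CCn1c(C(=O)N[C@H](CO)C(C)C)ccc1C(CC)(CC)c1ccc(OCS(=O)(=O)c2ccccc2)c(C)c1` gives 25500 nM
- compound 2 `CCn1c(C(=O)N[C@@H](CO)C(C)C)ccc1C(CC)(CC)c1ccc(OCS(=O)(=O)c2ccccc2)c(C)c1` gives 18800 nM
- compound 3 `CCn1c(C(=O)N[C@@H](CO)CCCO)ccc1C(CC)(CC)c1ccc(OCS(=O)(=O)c2ccccc2)c(C)c1` gives 29600 nM

Compound 3 shows no separation from the other two: the step of a 1.2-fold higher number from compound 1 to compound 3 (0.06 log units; within the scatter) and the step of a 1.6-fold higher number from compound 2 to compound 3 (0.20 log units; within the scatter) are both small. Given the fact that compounds 1 and 2 differ only in the configuration as drawn the step of a 1.4-fold lower number from compound 1 to compound 2 (0.13 log units; within the scatter) shows that configuration alone moves little here.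

The change to compound 4 `CCn1c(C(=O)NCCC(=O)O)ccc1C(CC)(CC)c1ccc(OCS(=O)(=O)c2ccccc2)c(C)c1` is a group of 5 heavy atoms (3 carbon, 2 oxygen; no ring) in place of a group of 7 heavy atoms (5 carbon, 2 oxygen; no ring), on an amide-type nitrogen and the entering group is 2-carboxyethyl. The earlier changes on the amide-type nitrogen stayed within the scatter, but none of them brought in 2-carboxyethyl, so their bearing is indirect. On the strength of compound 3 at 29600 nM and the step of a 1.6-fold higher number from compound 2 to compound 3 (0.20 log units; within the scatter) no step beyond the scatter is expected in this assay though the range is kept wide. The expected step is a 1.0-fold higher number from compound 3 to compound 4 (0.01 log units; within the scatter) as estimated here. Compound 4 is estimated at 30000 nM with an expected range from 12000 nM to 75000 nM in this estimate.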

Compound 4, half-maximal inhibitory concentration: > 50000 nM
Compound 4 gave a limit, no number; the forecaster's own chance of this, stated with the estimate: 15%; at least 1.6-fold (0.22 log units) between middle value and limit.
By their numbers in this assay, from the lowest: compounds 2, 1 and 3 (each within the scatter of the next). At a limit, above all of these: compound 4.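

In this assay compound 4 gives > 50000 nM, a limit and not a number, so the full size of its steps cannot be read. Going by these compounds alone, on the amide-type nitrogen, 2-carboxyethyl is the first change to pass the scatter, and only against one compound: an at least 2.6-fold higher number from compound 2 to compound 4 (0.42 log units; beyond the scatter) is beyond the scatter, while the floors of an at least 1.6-fold higher number from compound 3 to compound 4 (0.22 log units; that floor lies within the scatter) and an at least 1.9-fold higher number from compound 1 to compound 4 (0.29 log units; that floor lies within the scatter) lie within it. The whole group is exchanged in these steps, so they do not separate the carboxylic acid from the shorter chain or from the loss of the defined stereocentre.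

Open, as far as these compounds go, is whether a simple 3-hydroxypropyl chain on this nitrogen, with no carboxylic acid, would stay with compounds 1, 2 and 3. Also open, from the compounds shown here alone, is whether an amine or a longer carboxylic acid chain here would give a measurable number.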